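A few compounds are considered here, and "the series" means these few. Any claim that something is new, unique, unknown or untested is made for them only; others in the source may bear on it.

Measured so far:
Compound 1 `C=C[C@@](C)(/C=C/c1ccc(OC)cc1)CCC=C(C)C` — in a functional assay on HepG2 cells (Homo sapiens) for cytotoxicity, with a stated time of 72 h (a higher number here means that more compound is needed for the effect, a lower number that less compound is needed), compound 1 gives > 52000 nM, which is a limit of the assay and not a number.
Compound 2 `C=C[C@@](C)(/C=C/c1ccc(O)cc1)CC/C=C(\C)C=O` — in this assay compound 2 gives > 52000 nM, again only a limit.
Compound 3 `C=C[C@@](C)(/C=C/c1ccc(O)c(C=O)c1)CCC=C(C)C` — in this assay compound 3 gives > 52000 nM, also a limit.

Compound 3 therefore stands nowhere in particular within the set: no number has been reached for it, and (the limit of > 52000 nM in this assay, at which 3 of the 3 values shown sit), so none of the three can be set apart from another on what has been measured.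

Compound 4 `C=C[C@@](C)(/C=C/c1ccc(O)c(/C=C/c2ccc(Cl)cc2)c1)CCC=C(C)C` differs from compound 3 in one place: 2-(4-chlorophenyl)ethenyl in place of formyl on an aromatic carbon. Going by the values given here, no measured pair differs in a single place, so there is no measured step to lean on for this change; the three limits only show that the shared core with the smaller substituents gives no measurable effect in this assay.

For compound 4 the expectation is a value around 35000 nM, between 8000 nM and 120000 nM. The estimated step of an at least 1.4-fold lower number from compound 3 to compound 4 (0.17 log units; that floor lies within the scatter) is taken as a modest move toward less compound being needed, with a real chance that compound 4 is again expected to return only a limit.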

Compound 4, half-maximal effective concentration: > 52000 nM
Compound 4 was reported as a limit (the forecaster's own chance of this, stated with the estimate: 55%); middle value at least 1.4-fold (0.17 log units) away from the limit.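

Compound 3 and compound 4 both return only a limit, so the step between them cannot be read, and the series stays undivided: the limit of > 52000 nM in this assay, at which 4 of the 4 values shown sit.

The compounds shown leave open whether any change on the shared core reaches a measurable effect in this assay.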